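A few compounds are considered here, and "the series" means these few. Any claim that something is new, unique, unknown or untested is made for them only; others in the source may bear on it.

Measured so far:
compound 1 `CN(C[C@@H]1Cc2c(cccc2N2CCNCC2)CN1)[C@H]1CCCc2cccnc21` — in a functional assay on CCRF-CEM cells for agonist activity at C-X-C chemokine receptor type 4 (Homo sapiens), read by calcium flux, with a stated time of 25 min (on this read-out higher numbers stand for an effect only at larger amounts of compound and lower numbers for an effect already at smaller amounts), compound 1 gives > 30000 nM, which is a limit of the assay and not a number.
compound 2 `CCN(C[C@H]1Cc2c(cccc2N2CCNCC2)CN1)[C@H]1CCCc2cccnc21` — in this assay compound 2 gives > 30000 nM, again a limit rather than a number.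
compound 3 `Cc1cnc2c(c1)CCC[C@@H]2N(C)C[C@H]1Cc2c(cccc2N2CCNCC2)CN1` — in this assay compound 3 gives > 30000 nM, also a limit.

Compound 2 thus stands at the same limit as the other two measured compounds; no number separates any of them, so nothing can be said about order among them. The whole picture is summed up by the limit of > 30000 nM in this assay, at which 3 of the 3 values shown sit.

The unmeasured compound 4 `c1cnc2c(c1)CCC[C@@H]2N(CC1CCCCC1)C[C@H]1Cc2c(cccc2N2CCNCC2)CN1` differs from compound 2 in one place: cyclohexyl in place of methyl on a saturated chain carbon bound to an amine nitrogen. In words, cyclohexyl takes the place of methyl on a saturated chain carbon bound to an amine nitrogen.

Among the measured compounds shown here, no measured step exists to lean on, and every value so far is a limit. The expectation for the step from compound 2 to compound 4 in this assay is therefore none beyond the scatter, as expressed by a number no higher from compound 2 to compound 4 (the limit leaves the size open). Compound 4 is expected to give about 30000 nM, within 5000 nM to 100000 nM, most likely again reported only as a limit.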

Compound 4, half-maximal effective concentration: > 30000 nM
Compound 4: no number, only a limit; the forecaster's own chance of this, stated with the estimate: 80%; the middle value lies on the limit itself.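

In this assay compound 2 and compound 4 both stand at a limit and not at a number, so no step can be read between them. The compounds shown leave open what cyclohexyl in place of methyl does, and which structure would give a readable number, as the whole picture remains a single limit: the limit of > 30000 nM in this assay, at which 4 of the 4 values shown sit.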